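Working notes: methylsulfanyl to butyl on saturated ring carbon

This account rests on a few compounds, and the source may have more. Where it says the series, first, only, none or still open, it means among the compounds named here.

Measured so far in a functional assay on the whole organism (Pleural cavity) for inhibition, with Rattus norvegicus as the target, at a dose of 25 mg/kg; on this read-out lower numbers stand for less inhibition and higher numbers for more inhibition at the one dose given (going by the name of the read-out):
- compound 1 `CC1(C)C(=O)N(c2ccccc2Cl)c2ncccc21` gives 3%
- compound 2 `CC1(C)C(=O)N(c2ccc(S(C)(=O)=O)cc2)c2ncccc21` gives 0%
- compound 3 `CSC1(C)C(=O)N(c2ccccc2)c2ncccc21` gives 53%

Compound 3 stands highest of the three numbers in this assay. Its nearest neighbour is compound 1, whose number lies lower by a step beyond the scatter; compound 2 lies further still, also beyond the scatter. Among the measured compounds shown here, no pair among the three differs in a single place, so the numbers show only that compound 3 has the highest number and the two others sit far lower.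

The next compound, compound 4 `CCCCC1(C)C(=O)N(c2ccccc2)c2ncccc21`, differs from compound 3 in one place: butyl in place of methylsulfanyl on a saturated ring carbon. For the measured compounds named here, nothing in the measured set isolates this change, so the expectation rests on the shared core and the single high reading of compound 3.

In this assay the step from compound 3 to compound 4 is expected to run downward, a number 28 percentage points lower from compound 3 to compound 4 (beyond the scatter), of a size beyond the scatter, because compound 3 alone reaches 53% while every other reading of the series is at or near zero. Compound 4 is therefore estimated at 25%, with a range from 0% to 55%.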

Compound 4, a percentage reported as inhibition, in the whole organism at one dose (the size of the read-out at that dose, not a potency): 5%
The estimate for compound 4 lay 20 percentage points above the measured number, and the stated range covers the measured number.
By their numbers in this assay, from the lowest: compounds 2, 1 and 4 (each within the scatter of the next); then compound 3.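

In this assay, among the compounds shown here, butyl in place of methylsulfanyl on the saturated ring carbon gives a number 48 percentage points lower from compound 3 to compound 4 (beyond the scatter), the first change that can be read at a single place. The two compounds share everything else, so the shared core alone does not carry the high number of compound 3, and the group on this carbon has a large bearing on the reading at this dose. Nothing measured on these compounds accounts for the size of this step.

Methylsulfanyl and butyl differ both in the presence of sulfur and in chain length, so the compounds shown do not separate these two features, and a single pair says nothing about how far other groups on this carbon would carry the reading. Methoxy or ethylsulfanyl on the same carbon would help to separate them, as would a methyl or an ethyl chain, and an amine there would test whether a group of quite another kind can hold the reading of compound 3.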